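This account rests on a few compounds, and the source may have more. Where it says the series, first, only, none or still open, it means among the compounds named here.

Measured so far:
Compound 1, `COc1ccc(/C=C2\SC(=O)N(CCNC(=O)Nc3c(C)n(C)n(-c4ccccc4)c3=O)C2=O)cc1`: in an assay on isolated protein for inhibition of protein deacetylase HDAC6 (Homo sapiens), read by ELISA (a lower number here means a stronger inhibitor, a higher number a weaker inhibitor), compound 1 gives 258 nM.
Compound 2, `Cc1c(NC(=O)NCCN2C(=O)S/C(=C\c3ccc([N+](=O)[O-])cc3)C2=O)c(=O)n(-c2ccccc2)n1C`: in this assay compound 2 gives 144 nM.

Compound 2 and compound 1 share the same core and differ only in the group on the phenyl ring attached to the double-bonded chain carbon; the step of a 1.8-fold lower number from compound 1 to compound 2 (0.25 log units; within the scatter) is too small to tell the two apart, so neither can be called the stronger inhibitor.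

Compound 3, `COc1cc(/C=C2\SC(=O)N(CCNC(=O)Nc3c(C)n(C)n(-c4ccccc4)c3=O)C2=O)cc(OC)c1OC`, changes that same phenyl ring once more: 3,4,5-trimethoxyphenyl in place of 4-nitrophenyl on a double-bonded chain carbon bound to a double-bonded ring carbon. Within the data shown here, the only measured step that bears on this site is a 1.8-fold lower number from compound 1 to compound 2 (0.25 log units; within the scatter), an exchange of one small substituent for another on the same ring, which left the number essentially where it was. Among the measured compounds shown here, no measured step covers three methoxy groups on that ring, so the expectation rests on the single exchange seen. A step of similar size is expected, with no clear direction beyond the scatter. The step of a 1.6-fold higher number from compound 2 to compound 3 (0.20 log units; within the scatter) is the estimated outcome. Compound 3 is therefore expected to give about 230 nM, within a range from 80 nM to 700 nM.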

Compound 3, half-maximal inhibitory concentration: 475 nM
Estimate against measurement, compound 3: 2.1-fold (0.31 log units) below; low and high end bracket the measured number.
By their numbers in this assay, from the lowest: compounds 2, 1 and 3 (each within the scatter of the next, the first and the last beyond it).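

In this assay, among these compounds, this position now shows a step beyond the scatter for the first time: 3,4,5-trimethoxyphenyl in place of 4-nitrophenyl gives a 3.3-fold higher number from compound 2 to compound 3 (0.52 log units; beyond the scatter) on a double-bonded chain carbon bound to a double-bonded ring carbon. The same group in place of 4-methoxyphenyl gives a 1.8-fold higher number from compound 1 to compound 3 (0.27 log units; within the scatter) and stays within the scatter, so two extra methoxy groups on the ring produce no difference that can be read, and only compound 2 and compound 3, the two ends of this short series, can be told apart. No independent measurement accompanies these numbers to explain the separation between compound 2 and compound 3.

The compounds shown leave open what this position would give with an amine, a carboxylic acid or a halogen such as chlorine on the phenyl ring, or with a longer chain in place of the ring. They also leave open whether the separation between the 4-nitrophenyl and 3,4,5-trimethoxyphenyl groups would hold if another part of the shared core were changed.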